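Swapping Chloro for Fluoro on the Benzyl Group

The source may report more compounds than this note shows. Statements on the series, on what has been measured and on what is new or still open speak of the compounds shown alone.

Compound 1 `C=C(Br)C(=O)Nc1ccc(/C=C2\SC(=O)N(CC)C2=O)cc1` gives 1400 nM in a functional assay on HeLa cells (Homo sapiens) for cytotoxicity, read by cell counting, with a stated time of 4 days; a lower number here means a stronger inhibitor, a higher number a weaker inhibitor.
Compound 2 `Nc1cccc(/C=C2\SC(=O)N(Cc3cccc(Cl)c3)C2=O)c1` gives 250000 nM in this assay.
Compound 3 `Nc1ccc(/C=C2\SC(=O)N(Cc3cccc(Cl)c3)C2=O)cc1` gives 24000 nM in this assay.

Compound 3 stands second highest of these three numbers. Its nearest neighbour is compound 2, which gives the highest number, and its furthest is compound 1, which gives the lowest; both gaps lie beyond the scatter. Within the data shown here, the only measured step between two compounds that differ in a single place is a 10-fold lower number from compound 2 to compound 3 (1.02 log units; beyond the scatter), the move from 3-aminophenyl to 4-aminophenyl.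

Compound 4 `Nc1ccc(/C=C2\SC(=O)N(Cc3cccc(F)c3)C2=O)cc1` differs from compound 3 in a different place: fluoro in place of chloro on an aromatic carbon. Among the measured compounds shown here, no measured pair shows what exchanging these two halogens does, so the measured step between compound 2 and compound 3 does not bear on it directly. The change is small in size, one halogen for another, and with nothing in the data pointing one way, the expectation is a step that stays within the scatter, perhaps drifting slightly toward a higher number. The expected step is a 1.3-fold higher number from compound 3 to compound 4 (0.10 log units; within the scatter). Compound 4 is therefore estimated at 30000 nM in this assay, with a range from 10000 nM to 90000 nM.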

Compound 4, half-maximal inhibitory concentration: 250000 nM
Beside the measured number, compound 4's estimate is 8.3-fold (0.92 log units) below it, outside the stated range (above it).
By their numbers in this assay, from the lowest: compound 1; then compound 3; then compounds 2 and 4 (each within the scatter of the next).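

In this assay, putting fluoro in place of chloro gives a 10-fold higher number from compound 3 to compound 4 (1.02 log units; beyond the scatter), so this aromatic carbon on the benzyl group matters to the read-out, even though one halogen atom simply replaces another and the count of hydrogen-bond donors and acceptors stays the same. Among these compounds, until now, the only measured step was the move from 3-aminophenyl to 4-aminophenyl, a 10-fold lower number from compound 2 to compound 3 (1.02 log units; beyond the scatter), which said nothing about the benzyl end of the molecule; this result shows that a single-atom exchange there can also produce a step well beyond the scatter. No supporting measurement is available to explain why the two halogens differ so sharply here.

The compounds shown leave open whether chloro is especially favourable or fluoro especially unfavourable, and a bromo group, a methyl group or plain hydrogen on the same carbon would help to place the two halogens on a wider scale. They also leave open whether the exchange of chloro for fluoro would produce a step of similar size with 3-aminophenyl in place of 4-aminophenyl.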